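Swapping 4-methoxyphenyl for 3,4-dimethylphenyl on the shared core

The compounds below may be only part of what the source reports. "The series", "measured", "known", "first", "only" and "open" are said of these compounds alone.

In a functional assay on ECa-109 cells for inhibition, with ECa-109 cell line (Homo sapiens) as the target, read by sulforhodamine B assay (a lower number here means a stronger inhibitor, a higher number a weaker inhibitor), compound 1 `CCc1ccc(NC2=CC(=O)c3nc4n(c3C2=O)[C@H]2OC[C@@H](O)[C@H]2OC4)cc1` gives 3080 nM and compound 2 `O=C1C=C(Nc2ccc(C(F)(F)F)cc2)C(=O)c2c1nc1n2[C@H]2OC[C@@H](O)[C@H]2OC1` gives 5500 nM as measured numbers. Compound 3 `COc1ccc(NC2=CC(=O)c3nc4n(c3C2=O)[C@H]2OC[C@@H](O)[C@H]2OC4)cc1` stands only at a limit of > 4000 nM and has no number. Compound 4 `Cc1ccc(NC2=CC(=O)c3nc4n(c3C2=O)[C@H]2OC[C@@H](O)[C@H]2OC4)cc1C` differs from compound 3 in one place (3,4-dimethylphenyl in place of 4-methoxyphenyl on an amine nitrogen) and carries 3,4-dimethylphenyl in place of 4-methoxyphenyl on an amine nitrogen. Two measured swaps on an aromatic carbon bear on this: a 1.8-fold higher number from compound 1 to compound 2 (0.25 log units; within the scatter) and an at least 1.2-fold higher number from compound 1 to compound 3 (0.11 log units; that floor lies within the scatter) show nothing readable beyond the scatter, and a step that the limit leaves unreadable from compound 2 to compound 3 adds no size. No step beyond the scatter is therefore expected in this assay and an at least 1.0-fold lower number from compound 3 to compound 4 (0.02 log units; that floor lies within the scatter) is the expected size. Compound 4 is estimated at 3800 nM with 1800 nM to 8000 nM as its expected range.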

Compound 4, half-maximal inhibitory concentration: 2820 nM
Beside the measured number, compound 4's estimate is 1.3-fold (0.13 log units) above it, within the range that was stated.
By their numbers in this assay, from the lowest: compounds 4, 1 and 2 (each within the scatter of the next).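

In this assay the 3,4-dimethylphenyl group on the amine nitrogen stays level with both 4-(trifluoromethyl)phenyl (a 2.0-fold lower number from compound 2 to compound 4 (0.29 log units; within the scatter)) and 4-ethylphenyl (a 1.1-fold lower number from compound 1 to compound 4 (0.04 log units; within the scatter)), so a second methyl-bearing ring carbon brings no readable change at this position. Against 4-methoxyphenyl, the change shows only a floor (an at least 1.4-fold lower number from compound 3 to compound 4 (0.15 log units; that floor lies within the scatter)). Compound 3 remains at a limit and has no number: the limit of > 4000 nM in this assay, at which 1 of the 4 values shown sits.

From the compounds shown here alone, whether an amine or a carboxylic acid on this phenyl ring would move the number beyond the scatter remains open. So does the true size of the step from 4-methoxyphenyl.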